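The source may hold more compounds than are shown below. What is called first, only, known or untested is meant among the compounds shown, and "the series" means these compounds.

In a functional assay on MT4 cells (Homo sapiens) for inhibition (on this read-out higher numbers stand for weaker inhibition and lower numbers for stronger inhibition), compound 3 (`COC(=O)c1[nH]c2ccc(Cl)cc2c1Sc1ccccc1`) gives 1500 nM and compound 1 (`[O-][S+](Cc1[nH]c2ccc(Cl)cc2c1Sc1ccccc1)c1ccccc1`) gives 800 nM in the same read-out. These two values lie within the usual scatter of each other, so no order can be drawn between them. Compound 3 therefore stands level with the only other numeric result in the series.

Compound 2 (`[O-][S+](Cc1[nH]c2ccccc2c1[S+]([O-])c1ccccc1)c1ccccc1`) returns > 3000 nM in this assay as a limit and not a number.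

The step under consideration leads to compound 4 (`NC(=O)c1[nH]c2ccc(Cl)cc2c1Sc1ccccc1`), not yet measured, which carries amino in place of methoxy on a carbonyl carbon. The same difference reads as methoxycarbonyl to carbamoyl (amino in place of methoxy on a carbonyl carbon).

Among the compounds with values here, no measured pair isolates this change, so the size assigned to it is a judgement and the margins stay wide. In this assay a lower number, meaning stronger inhibition, is expected, by somewhat more than the scatter, although a result within the scatter cannot be excluded. The estimated step is a 6.0-fold lower number from compound 3 to compound 4 (0.78 log units; beyond the scatter) in this tentative picture. For compound 4 the expected value is 250 nM with an estimated range of 50 nM to 1200 nM in this read-out.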

Compound 4, concentration for 95% inhibition: 200 nM
Compound 4: middle estimate off by 1.3-fold (0.10 log units), on the high side, within the range that was stated.
By their numbers in this assay, from the lowest: compound 4; then compounds 1 and 3 (each within the scatter of the next). At a limit, above all of these: compound 2.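

In this assay, within the data shown here, amino in place of methoxy on a carbonyl carbon gives the first readable step: a 7.5-fold lower number from compound 3 to compound 4 (0.88 log units; beyond the scatter). The earlier compounds shown here gave no step at all, and compound 1 and compound 3 could not be ordered, so nothing yet showed that the read-out responds to a change at this place. The group on this carbonyl carbon now proves to matter, and compound 4, at 200 nM, holds the lowest number shown, while compound 1 stands at 800 nM.

This rests on a single pair with one core and one aromatic carbon neighbour on the carbonyl carbon, and nothing measured in the series bears on why the step has this size. Going by these compounds, how a methylamino group, a dimethylamino group or a hydroxyl on the same carbonyl carbon would read stays open, as does whether the step would hold on the core of compound 2 or with a longer chain in place of the methoxy.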